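Extending a methoxy to an ethoxy on a hydrazone core

The source may report more compounds than this note shows. Statements on the series, on what has been measured and on what is new or still open speak of the compounds shown alone.

Going by the values given here, compound 2 `COc1ccc(/C=N/NC(=O)c2cnccn2)cc1` stands lowest of the two numbers so far in an ADME assay on J774 cells (Mus musculus) for cytotoxicity, read by MTT assay, with a stated time of 48 h, tested at 100 ug/mL; a lower number here means a stronger effect, a higher number a weaker effect of the compound at the concentration tested: compound 2 gives 55%, while compound 1 `O=C(N/N=C/c1ccccc1)c1cnccn1` gives 75%. Compound 3 `CCOc1ccc(/C=N/NC(=O)c2cnccn2)cc1` differs from compound 2 by methyl in place of hydrogen on a saturated chain carbon bound to an oxygen on an aromatic ring. Among the compounds with values here, the only measured step, a number 20 percentage points lower from compound 1 to compound 2 (beyond the scatter), concerns a different change, so no step directly matches this one. Given that, only a small shift is expected: for compound 3 the expected step is a number 5 percentage points lower from compound 2 to compound 3 (within the scatter). The estimate for compound 3 in this assay is 50%, with a range from 35% to 70%.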

Compound 3, a percentage reported as activity, at one concentration (the size of the read-out at that concentration, not a potency): 98%
Compound 3: middle estimate off by 48 percentage points, on the low side; the measured number lies above the stated range.
By their numbers in this assay, from the lowest: compound 2; then compound 1; then compound 3.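

Lengthening methoxy to ethoxy gives a number 43 percentage points higher from compound 2 to compound 3 (beyond the scatter) in this assay, so a single added methyl on this chain reverses the direction set by the methoxy group. The ethoxy group also differs from plain hydrogen in the opposite direction to methoxy, with a number 23 percentage points higher from compound 1 to compound 3 (beyond the scatter), so the read-out here does not follow the mere presence of an alkoxy group. No evidence at hand explains this reversal.

From the compounds shown here alone, whether a propoxy group or a longer chain would keep the number high remains open, as does how a hydroxy group would compare.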